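Allyl ether of compound 2: an estimate at the limit

This account rests on a few compounds, and the source may have more. Where it says the series, first, only, none or still open, it means among the compounds named here.

Compound 1 `CC(C)(C)[Si](C)(C)O[C@H]1CCCO[C@@H]1CO` gives > 100000 nM in a functional assay on SW1573 cells (Homo sapiens) for antiproliferative activity, read by sulforhodamine B assay, with a stated time of 48 h (on this read-out higher numbers stand for weaker inhibition of growth and lower numbers for stronger inhibition of growth), and this is a limit, not a number. Compound 2 `CC(C)(C)[Si](C)(C)O[C@@H]1CCCO[C@@H]1CO` gives > 100000 nM in this assay and this too is only a limit. Compound 3 `O=C1COC[C@H]2OCCC[C@@H]2O1` gives > 100000 nM in this assay and this is again a limit. Compound 2 therefore offers no number as a starting point and stands at the same limit as the other two measured compounds.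

Compound 4 `C=CCOC[C@H]1OCCC[C@H]1O[Si](C)(C)C(C)(C)C` carries allyl in place of hydrogen on an oxygen on a saturated carbon of compound 2 allyl in place of hydrogen on an oxygen on a saturated carbon and so reads as hydroxymethyl to (allyloxy)methyl. For the measured compounds named here, the one measured step that the two limits leave unreadable from compound 1 to compound 2 has no readable size and concerns only the configuration as drawn the fact that compounds 1 and 2 differ only in the configuration as drawn rather than a change of this kind. Because of the limit of > 100000 nM in this assay, at which 3 of the 3 values shown sit, the series holds no measured size to carry over.

No clear shift in either direction is expected in this assay from this change. The estimated step of a number no higher from compound 2 to compound 4 (the limit leaves the size open) is small and has no firm direction. For compound 4 the expected value is 100000 nM with an estimated range from 40000 nM to 200000 nM and a report as a limit alone is the likelier outcome.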

Compound 4, concentration for 50% growth inhibition: 18000 nM
Compound 4: the middle estimate sits 5.6-fold (0.74 log units) above what was measured; the measured number lies below the stated range.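

In this assay, hydroxymethyl to (allyloxy)methyl gives an at least 5.5-fold lower number from compound 2 to compound 4 (0.74 log units; beyond the scatter), so this oxygen on a saturated carbon accepts allyl in place of hydrogen and measurable inhibition of growth appears with that change. The size is a lower bound, as the starting point is a limit and not a number; the true step may be larger, but the direction is clear and lies beyond the scatter. Compound 4 is also the only compound shown that gives the series a number to work from, while the others remain at a single limit: the limit of > 100000 nM in this assay, at which 3 of the 4 values shown sit.

One compound cannot separate a contribution of allyl itself from that of any group on this oxygen, and an ether with a saturated propyl chain or a benzyl group, or an amine-bearing chain, would be needed to test how specific the change is. As far as these compounds go, it also remains open whether the same allyl ether on the configuration of compound 1 would behave alike, and the step between compound 1 and compound 2 cannot be read.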